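Shifting one aryl group on two related cores

The source may report more compounds than this note shows. Statements on the series, on what has been measured and on what is new or still open speak of the compounds shown alone.

Compound 1 `Cc1cccc(NNC(=O)c2ccc(NS(=O)(=O)c3cnc(O)nc3O)cc2)c1` carries a 3-methylphenyl on an amine nitrogen whose other neighbour is an amide-type nitrogen. In a functional assay on A549 cells (Homo sapiens) for antiproliferative activity, read by MTT assay, with a stated time of 24 h (a higher number here means a weaker inhibitor, a lower number a stronger inhibitor), compound 1 gives only a limit, > 20000 nM. Compound 2 `O=C(NNc1ccccc1Cl)c1ccc(NS(=O)(=O)c2cnc(O)nc2O)cc1` differs from it by 2-chlorophenyl in place of 3-methylphenyl on an amine nitrogen, and in this assay compound 2 gives 3340 nM. The step of an at least 5.9-fold lower number from compound 1 to compound 2 (0.77 log units; beyond the scatter) is known only as a bound on its size because compound 1 sits at the limit of > 20000 nM in this assay, at which 2 of the 3 values shown sit.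

Compound 3 `Cc1cccc(NNC(=O)c2ccccc2NS(=O)(=O)c2cnc(O)nc2O)c1` has the same atoms as compound 1 joined differently; the difference between the two cores is not broken down here. In this assay compound 3 likewise gives only a limit, > 20000 nM.

Compound 4 `O=C(NNc1ccccc1Cl)c1ccccc1NS(=O)(=O)c1cnc(O)nc1O` is not yet measured. It differs from compound 3 by 2-chlorophenyl in place of 3-methylphenyl on an amine nitrogen, the same change at the same kind of place as the change from compound 1 to compound 2, and it occurs twice among the four compounds. Whether the second core carries the change as well is open, since compound 3 gives no number to build on. The expectation for compound 4 is a step of an at least 2.2-fold lower number from compound 3 to compound 4 (0.34 log units; beyond the scatter) in this assay, set beside an at least 5.9-fold lower number from compound 1 to compound 2 (0.77 log units; beyond the scatter) on the first core. Compound 4 is expected at about 9000 nM, with a range from 2500 nM to 20000 nM.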

Compound 4, half-maximal inhibitory concentration: 5480 nM
The estimate for compound 4 lay 1.6-fold (0.22 log units) above the measured number; the range from low to high includes it.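

In this assay, 2-chlorophenyl in place of 3-methylphenyl on an amine nitrogen gives an at least 3.6-fold lower number from compound 3 to compound 4 (0.56 log units; beyond the scatter), so the lower number seen on the core of compound 1 also appears on the core of compound 3, and in this pair of cores the change carries over in direction. The two steps are both bounds, so their sizes cannot be ranked and nothing can be said about whether one core responds more strongly than the other: the same change on two cores in this assay, an at least 5.9-fold lower number (0.77 log units; beyond the scatter) from compound 1 to compound 2 and an at least 3.6-fold lower number (0.56 log units; beyond the scatter) from compound 3 to compound 4; the limit leaves it open whether they differ Neither step has a true size, and the pairs show only that each 2-chlorophenyl compound gives a measurable number where its 3-methylphenyl partner does not: the limit of > 20000 nM in this assay, at which 2 of the 4 values shown sit.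

The compounds shown cover only these two aryl groups on two cores, and since the change replaces one substituted ring with another, they do not separate the gain from the chlorine from any loss from the methyl group. An unsubstituted phenyl on the same amine nitrogen would give a reference point on each core, and a ring carrying bromine, a methoxy group or a nitrile would show whether the lower number is specific to 2-chlorophenyl.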